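A few compounds are considered here, and "the series" means these few. Any claim that something is new, unique, unknown or untested is made for them only; others in the source may bear on it.

Measured in an assay on isolated protein for inhibition of Maltase-glucoamylase (Homo sapiens); a lower number here means a stronger inhibitor, a higher number a weaker inhibitor:
compound 1 `O=c1oc2ccc(Cl)cc2c(O)c1C(c1ccc(Cl)cc1Cl)c1c(O)c2cc(Cl)ccc2oc1=O` gives 16500 nM;
compound 2 `COc1ccc(C(c2c(O)c3cc(Cl)ccc3oc2=O)c2c(O)c3cc(Cl)ccc3oc2=O)cc1O` gives 113000 nM;
compound 3 `CCOc1cc(C(c2c(O)c3cc(Cl)ccc3oc2=O)c2c(O)c3cc(Cl)ccc3oc2=O)ccc1O` gives 57100 nM.

Compound 3 holds the second highest of the three numbers; its nearest neighbour is compound 2, a pair within the scatter, while compound 1 sits further off beyond it. Compound 4 `COc1cc(C(c2c(O)c3cc(Cl)ccc3oc2=O)c2c(O)c3cc(Cl)ccc3oc2=O)cc(OC)c1OC` carries 3,4,5-trimethoxyphenyl in place of 3-ethoxy-4-hydroxyphenyl on a saturated chain carbon bound to two aromatic carbons. Going by the values given here, two measured steps bear on the aryl on that saturated chain carbon: a 6.8-fold higher number from compound 1 to compound 2 (0.84 log units; beyond the scatter) and a 3.5-fold higher number from compound 1 to compound 3 (0.54 log units; beyond the scatter) gave higher numbers for the 3-hydroxy-4-methoxyphenyl and 3-ethoxy-4-hydroxyphenyl groups than for 2,4-dichlorophenyl, whereas a 2.0-fold lower number from compound 2 to compound 3 (0.30 log units; within the scatter) moved little. Compound 4 keeps a methoxy-bearing phenyl, so the step of a 1.3-fold higher number from compound 3 to compound 4 (0.12 log units; within the scatter) is expected to be small, at most slightly upward. Compound 4 is estimated at 75000 nM, range 25000 nM to 220000 nM.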

Compound 4, half-maximal inhibitory concentration: 128000 nM
The estimate for compound 4 lay 1.7-fold (0.23 log units) below the measured number; the range from low to high includes it.
By their numbers in this assay, from the lowest: compound 1; then compounds 3, 2 and 4 (each within the scatter of the next, the first and the last beyond it).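

In this assay, going by these compounds alone, 3,4,5-trimethoxyphenyl is the first group at this position with no hydroxy, and it weakens inhibition relative to 3-ethoxy-4-hydroxyphenyl (a 2.2-fold higher number from compound 3 to compound 4 (0.35 log units; beyond the scatter)). Yet it cannot be told apart from 3-hydroxy-4-methoxyphenyl (a 1.1-fold higher number from compound 2 to compound 4 (0.05 log units; within the scatter)), so the presence of a hydroxy does not by itself sort these groups. The 2,4-dichlorophenyl group remains ahead of all three oxygen-bearing groups, including this one (a 7.8-fold higher number from compound 1 to compound 4 (0.89 log units; beyond the scatter)).

No evidence in hand explains these steps. Open, going by these compounds, is how an unsubstituted phenyl or an amine-bearing phenyl would behave on the saturated chain carbon bound to two aromatic carbons.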